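Aryl change on the amine nitrogen of compound 2

The compounds below may be only part of what the source reports. "The series", "measured", "known", "first", "only" and "open" are said of these compounds alone.

The compounds share the core of compound 1 `O=C1C(Nc2ccccc2)=CC(=O)c2c1nc1n2[C@H]2OC[C@@H](O)[C@H]2OC1`. In a functional assay on HeLa cells (Homo sapiens) for inhibition, read by sulforhodamine B assay (a lower number here means a stronger inhibitor, a higher number a weaker inhibitor), compound 1 gives > 8000 nM, which is a limit of the assay and not a number. Compound 3 `O=C1C(N2CCCC2)=CC(=O)c2c1nc1n2[C@H]2OC[C@@H](O)[C@H]2OC1` gives > 16000 nM, which is also a limit. Going by the values given here, compound 2 `O=C1C=C(Nc2ccccc2F)C(=O)c2c1nc1n2[C@H]2OC[C@@H](O)[C@H]2OC1` gives 5120 nM, the only true number so far, so it cannot be ranked exactly against the other two compounds.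

The next compound is compound 4 `O=C1C=C(Nc2ccc(Br)cc2)C(=O)c2c1nc1n2[C@H]2OC[C@@H](O)[C@H]2OC1`, which has 4-bromophenyl in place of 2-fluorophenyl on an amine nitrogen. Among the compounds with values here, the only measured step is a step that the two limits leave unreadable from compound 1 to compound 3. It gives no size to carry over, and it concerns a different change at this position. Within the data shown here, no measured step covers an exchange of one substituted phenyl for another. The expectation therefore rests on compound 2 alone, at 5120 nM, and no direction can be argued from the data. In this assay the expectation is no shift beyond the scatter, with the estimated step being a 1.0-fold lower number from compound 2 to compound 4 (0.01 log units; within the scatter). The range is kept wide, and a result reported only as a limit would not be surprising. For compound 4 the estimated value is 5000 nM, with an expected range from 1800 nM to 14000 nM.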

Compound 4, half-maximal inhibitory concentration: 3830 nM
Estimate against measurement, compound 4: 1.3-fold (0.12 log units) above; low and high end bracket the measured number.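

In this assay, going by these compounds alone, the exchange of 2-fluorophenyl for 4-bromophenyl on the amine nitrogen gives the first step at this position with true numbers at both ends: a 1.3-fold lower number from compound 2 to compound 4 (0.13 log units; within the scatter). The halogen and its place on the phenyl ring therefore both differ between these two compounds, yet the pair cannot be told apart in this assay, so this single exchange gives no handle on the number and no order among the two aryl groups. The data shown offer no explanation for this result, and nothing here separates the contribution of the halogen from that of its place on the ring.

The step from compound 1 to compound 3 joins two limits of the assay and cannot be read, so the pyrrolidin-1-yl change still has no size. Open, going by these compounds, is whether any group on this amine nitrogen moves the number beyond the scatter, for example a phenyl ring carrying a carboxylic acid or a dimethylamino group, or a benzyl group that sets a carbon chain between the nitrogen and the ring.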